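The compounds below may be only part of what the source reports. "The series", "measured", "known", "first", "only" and "open" are said of these compounds alone.

Three compounds of a shared core have been run through a functional assay on SF-268 cells (Homo sapiens) for cytotoxicity, read by sulforhodamine B assay, with a stated time of 48 h, tested at 0.1 uM; a lower number here means a stronger effect, a higher number a weaker effect of the compound at the concentration tested. Compound 1, `COc1cc(-c2cc(/C=C/C(=O)c3ccc(N)cc3)[nH]n2)cc(OC)c1OC`, gives 106% in this assay. Compound 2, `COc1cc(-c2cc(/C=C/C(=O)c3ccc(Cl)c(Cl)c3)[nH]n2)cc(OC)c1OC`, gives 92%, and compound 3, `COc1ccc(C(=O)/C=C/c2cc(-c3cc(OC)c(OC)c(OC)c3)n[nH]2)cc1OC`, gives 89%. The changes among them all sit on the aryl ring attached to the carbonyl carbon: a number 14 percentage points lower from compound 1 to compound 2 (beyond the scatter), a number 17 percentage points lower from compound 1 to compound 3 (beyond the scatter), while a number 3 percentage points lower from compound 2 to compound 3 (within the scatter). Compound 3 thus holds the lowest number of the three, with compound 2 within the scatter of it and compound 1 alone clearly higher.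

Compound 4, `COc1ccc(C(=O)/C=C/c2cc(-c3cc(OC)c(OC)c(OC)c3)n[nH]2)cc1`, is the next member and has not yet been measured. It differs from compound 3 by hydrogen in place of methoxy on an aromatic carbon, again on the aryl ring of the carbonyl carbon. Among the compounds with values here, no measured step removes a single methoxy from this ring, so the prediction rests on the neighbouring comparisons. The step from compound 2 to compound 3 shows that exchanging the whole substitution pattern on this ring moved the read-out only within the scatter, so a change of one group is expected to produce no step beyond the scatter in this assay. Compound 4 is therefore estimated at 92%, within 78% to 106%, meaning an expected a number 3 percentage points higher from compound 3 to compound 4 (within the scatter).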

Compound 4, a percentage reported as activity, at one concentration (the size of the read-out at that concentration, not a potency): 91%
The estimate for compound 4 lay 1 percentage points above the measured number; measured number inside the range.
By their numbers in this assay, from the lowest: compounds 3, 4 and 2 (each within the scatter of the next); then compound 1.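

Taking away one methoxy, so that 3,4-dimethoxyphenyl becomes 4-methoxyphenyl, is the first change of a single group on this ring, and in this assay it gives a number 2 percentage points higher from compound 3 to compound 4 (within the scatter), so the read-out at this concentration does not depend on that methoxy. The 4-methoxyphenyl group also stands level with 3,4-dichlorophenyl, with a number 1 percentage points lower from compound 2 to compound 4 (within the scatter), whereas exchanging the amino group for methoxy gives a number 15 percentage points lower from compound 1 to compound 4 (beyond the scatter), which leaves compound 1 as the only one of the four set apart from the rest. Nothing at hand explains why the amino compound stands apart from the others.

On these data alone, it remains open whether an unsubstituted phenyl ring, or a hydroxyl group or a carboxylic acid in place of the remaining methoxy, would stay with compound 2, compound 3 and compound 4 or move towards compound 1. Since all four values come from a single concentration, they also leave open whether these ring changes would separate the compounds at higher concentrations.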